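Compound 1 and its (carboxymethyl)amino analogue, compound 4

A few compounds are considered here, and "the series" means these few. Any claim that something is new, unique, unknown or untested is made for them only; others in the source may bear on it.

Measured in a functional assay on Huh-7 cells (Homo sapiens) for cytotoxicity, read by MTT assay, with a stated time of 3 days; on this read-out higher numbers stand for lower toxicity in this test and lower numbers for higher toxicity in this test:
Compound 1 `OC[C@H]1O[C@@H](n2cnc3c(Cn4ccc5ccccc54)ncnc32)[C@H](O)[C@@H]1O`: > 250000 nM, a limit
Compound 2 `OC[C@H]1O[C@@H](n2cnc3c(COc4ccccn4)ncnc32)[C@H](O)[C@@H]1O`: > 250000 nM, a limit
Compound 3 `O=C1CCCN1Cc1ncnc2c1ncn2[C@@H]1O[C@H](CO)[C@@H](O)[C@H]1O`: 45000 nM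

Compound 1 gives no exact number, only the limit > 250000 nM. This is the limit of > 250000 nM in this assay, at which 2 of the 3 values shown sit. Compound 4 `O=C(O)CNCc1ncnc2c1ncn2[C@@H]1O[C@H](CO)[C@@H](O)[C@H]1O` has not yet been measured. It differs from compound 1 as follows: (carboxymethyl)amino in place of 1H-indol-1-yl on a saturated chain carbon bound to an aromatic carbon. In words, (carboxymethyl)amino stands in place of 1H-indol-1-yl on a saturated chain carbon bound to an aromatic carbon.

Two measured changes at the same place bear on this one. With (pyridin-2-yl)oxy entering, the result is a step that the two limits leave unreadable from compound 1 to compound 2. With 2-oxopyrrolidin-1-yl entering, the result is an at least 5.5-fold lower number from compound 1 to compound 3 (0.74 log units; beyond the scatter). One replacement therefore gave a lower number and the other gave none that can be read. A modest step to a lower number is thus expected in this assay, though compound 4 may well give only a limit too. The estimated change is an at least 1.6-fold lower number from compound 1 to compound 4 (0.22 log units; that floor lies within the scatter). For compound 4 the expected value is 150000 nM, with an estimated range from 40000 nM to 250000 nM.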

Compound 4, half-maximal cytotoxic concentration: > 100000 nM
Compound 4 gave a limit, no number (the forecaster's own chance of this, stated with the estimate: 60%); the middle value does not contradict the limit.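

Compound 4 gives > 100000 nM in this assay, and this is a limit. The open-chain (carboxymethyl)amino group, which has no ring, thus stands at this saturated chain carbon with an at least 2.2-fold higher number from compound 3 to compound 4 (0.34 log units; beyond the scatter), so the lower number of compound 3 does not carry over to this replacement of 1H-indol-1-yl. Among the four compounds, only compound 3 gives a number rather than a limit, while the steps joining compound 4 to compound 1 and to compound 2 cannot be read.

As far as these compounds go, how far the true value of compound 4 lies beyond its limit remains open, and so does its order relative to compound 1 and compound 2. Also open, from the compounds shown here alone, is whether a plain amine, or a longer chain ending in a carboxylic acid, would stay clear of the value of compound 3 in this assay.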